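Methoxy in Place of Hydrogen on the Hydrazone Aryl Ring

A few compounds are considered here, and "the series" means these few. Any claim that something is new, unique, unknown or untested is made for them only; others in the source may bear on it.

Of the compounds shown here, three have been tested in a functional assay on the whole organism (strain Wistar) for inhibition, with Rattus norvegicus as the target, read by paw edema, with a stated time of 4 h, at a dose of 10 mg/kg by the intraperitoneal route; a higher number here means more inhibition at the dose given (going by the name of the read-out), a lower number less inhibition. Compound 1 `COc1cccc(/C=N/NC(=O)c2cccnc2Nc2cccc(C(F)(F)F)c2)c1` gives 14.9% in this assay, compound 2 `CNc1ncccc1C(=O)N/N=C/c1ccccc1` gives 14.8%, and compound 3 `CNc1ncccc1C(=O)N/N=C/c1ccc(Cl)cc1` gives 18.2%. Compound 2 stands lowest of the three numbers, yet its nearest neighbour, compound 1, sits within the scatter, and so does compound 3 at the far end. Among the compounds with values here, the only single-point step among them, a number 3.4 percentage points higher from compound 2 to compound 3 (within the scatter), stays within the scatter.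

Compound 4 `CNc1ncccc1C(=O)N/N=C/c1cccc(OC)c1` is not yet measured. It differs from compound 2 by methoxy in place of hydrogen on an aromatic carbon, placed on an aromatic carbon of a six-membered aromatic ring of carbon only, meta to a large group. Compound 1 also carries a methoxy group, and its value lies beside that of compound 2. With one bearing step inside the scatter and no contrary evidence, no change beyond the scatter is expected in this assay. Compound 4 is therefore estimated at 16%, between 8% and 25%, a step expected to be a number 1.2 percentage points higher from compound 2 to compound 4 (within the scatter).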

Compound 4, a percentage reported as inhibition, in the whole organism at one dose (the size of the read-out at that dose, not a potency): 42.3%
Compound 4: middle estimate off by 26.3 percentage points, on the low side; the whole stated range lies below it.
By their numbers in this assay, from the lowest: compounds 2, 1 and 3 (each within the scatter of the next); then compound 4.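

In this assay, methoxy on this aromatic carbon, meta to a large group, is the first single change shown to move the number beyond the scatter: a number 27.5 percentage points higher from compound 2 to compound 4 (beyond the scatter). Methoxy alone does not bring this gain, as compound 1 carries methoxy too, and with methyl in place of 3-(trifluoromethyl)phenyl on the nitrogen there is a number 27.4 percentage points higher from compound 1 to compound 4 (beyond the scatter). Nothing measured here accounts for the rise.

Going by these compounds, what a hydroxy group, a longer ethoxy chain or a dimethylamino group would give on this same carbon remains open, so it is unclear how specific the effect is to methoxy. On these data alone, with a single dose and a single time point, it is also open whether the gain would hold at other doses or times.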